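The source may report more compounds than this note shows. Statements on the series, on what has been measured and on what is new or still open speak of the compounds shown alone.

Measured compounds:
- compound 1 `Cc1nc(S(C)(=O)=O)ccc1Oc1ncnc(OC2CCN(C(=O)O[C@@H](C)CF)CC2)c1F`: 1680 nM
- compound 2 `Cc1nc(S(C)(=O)=O)ccc1Oc1ncnc(OC2CCN(C(=O)SC(C)(C)C)CC2)c1F`: 30.7 nM

Two compounds of the series have been run in a functional assay on isolated protein for inhibition of Glucose-dependent insulinotropic receptor (Rattus norvegicus), read by HTRF and cAMP accumulation; a higher number here means that more compound is needed for the effect, a lower number that less compound is needed. Among the compounds with values here, compound 1 gives 1680 nM; compound 2 gives 30.7 nM and stands as the lower of the two numbers, the single step of a 55-fold lower number from compound 1 to compound 2 (1.74 log units; beyond the scatter) being large and well beyond the scatter. Within the data shown here, that step is the only one available and it changes the same position on the carbonyl carbon that is altered here.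

Compound 3 `Cc1nc(S(C)(=O)=O)ccc1Oc1ncnc(OC2CCN(C(=S)OC(C)C)CC2)c1F` is not yet measured. It differs from compound 2 by a group of 6 heavy atoms (4 carbon, 1 oxygen, 1 sulfur; no ring) in place of a group of 7 heavy atoms (5 carbon, 1 oxygen, 1 sulfur; no ring), on an amine nitrogen in a ring: the ((tert-butyl)sulfanyl)carbonyl leaves and a group with one carbon fewer, its sulfur now double-bonded and its oxygen bearing the chain, enters on the amine nitrogen in the ring. Among the measured compounds shown here, no measured pair shows this exact change; the step from compound 1 to compound 2 only shows that this position moves the number a great deal. A moderate step upward from compound 2 is therefore expected, a 2.9-fold higher number from compound 2 to compound 3 (0.47 log units; beyond the scatter), short of the gap back to compound 1. Compound 3 is estimated at 90 nM in this assay, with a range of 25 nM to 350 nM.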

Compound 3, half-maximal effective concentration: 1050 nM
Compound 3: the middle estimate sits 12-fold (1.07 log units) below what was measured; the whole stated range lies below it.
By their numbers in this assay, from the lowest: compound 2; then compounds 3 and 1 (each within the scatter of the next).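

In this assay there is a 34-fold higher number from compound 2 to compound 3 (1.53 log units; beyond the scatter) and so sulfur in the group on the amine nitrogen is not enough on its own to keep the number low: compound 3 also holds a sulfur, double-bonded, with its oxygen bearing the chain. Compound 3 stands level with compound 1, at a 1.6-fold lower number from compound 1 to compound 3 (0.20 log units; within the scatter) even though the carbonyl and the fluorine-bearing chain of compound 1 are both gone, so among these three compounds only the ((tert-butyl)sulfanyl)carbonyl of compound 2 gives the low number, while both groups with an oxygen bearing the chain give high numbers. Nothing at hand bears on why these groups differ.

On these data alone, the change from compound 2 to compound 3 alters the atom bearing the chain, the double-bonded atom and the chain itself all at once, so the share of each remains open. As far as these compounds go, a tert-butoxycarbonyl group or an isopropylsulfanylcarbonyl group on the same amine nitrogen would separate these parts, and whether a urea with a tert-butyl chain fits the same picture is also open.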